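Swapping the Sulfamoylphenyl for Carbamoylphenyl in a Dog Study

The source may report more compounds than this note shows. Statements on the series, on what has been measured and on what is new or still open speak of the compounds shown alone.

Compound 1 `NS(=O)(=O)c1ccccc1-n1nc(C(F)(F)F)c2c1C(=O)N(c1ccc(-c3ccccc3CN3CC[C@@H](O)C3)cc1)CC2`: 3.5 L/kg
Compound 2 `CN(C)Cc1ccccc1-c1ccc(N2CCc3c(C(F)(F)F)nn(-c4ccccc4S(N)(=O)=O)c3C2=O)cc1`: 8.1 L/kg

In an in vivo ADME assay on the whole organism for pharmacokinetics, with Canis familiaris (Canis lupus familiaris) as the target (a lower number here means that more of the compound stays in the plasma, a higher number that more of the compound sits outside the plasma), compound 1 gives 3.5 L/kg, the lowest of the two numbers; its nearest neighbour is compound 2 at 8.1 L/kg, and the step of a 2.3-fold higher number from compound 1 to compound 2 (0.36 log units; beyond the scatter) concerns the amine only. Compound 3 `NC(=O)c1cccc(-n2nc(C(F)(F)F)c3c2C(=O)N(c2ccc(-c4ccccc4CN4CC[C@@H](O)C4)cc2)CC3)c1` differs from compound 1 by 3-carbamoylphenyl in place of 2-sulfamoylphenyl on an aromatic nitrogen. Among the compounds with values here, no measured step touches that position, so no guidance exists beyond the shared core. The expected step is therefore none beyond the scatter, no change at the digits printed from compound 1 to compound 3 (within the scatter), and compound 3 is estimated at 3.5 L/kg, within 1.5 L/kg to 8 L/kg.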

Compound 3, volume of distribution at steady state: 2.6 L/kg
Beside the measured number, compound 3's estimate is 1.3-fold (0.13 log units) above it; low and high end bracket the measured number.
By their numbers in this assay, from the lowest: compounds 3 and 1 (each within the scatter of the next); then compound 2.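

Replacing 2-sulfamoylphenyl with 3-carbamoylphenyl on the aromatic nitrogen, the first change seen at this position, gives in this assay a 1.3-fold lower number from compound 1 to compound 3 (0.13 log units; within the scatter). Thus the exchange of both the group and its place on the phenyl ring leaves the reading within the scatter, whereas the amine change gave a 2.3-fold higher number from compound 1 to compound 2 (0.36 log units; beyond the scatter). Nothing available here accounts for this result.

Going by these compounds, whether 2-carbamoylphenyl or 3-sulfamoylphenyl would behave the same stays open, so the group and its place cannot be separated. Also open, on these data alone, is whether a carboxylic acid in place of the carbamoyl group would hold the reading.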